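Phenyl in place of benzyl on the ring nitrogen

A few compounds are considered here, and "the series" means these few. Any claim that something is new, unique, unknown or untested is made for them only; others in the source may bear on it.

Compound 1 `N#Cc1ccc(Nc2nc(Oc3ccnc4ccccc34)nc(N3CCN(c4ccccn4)CC3)n2)cc1C(F)(F)F` and compound 2 `N#Cc1ccc(Nc2nc(Oc3ccnc4ccccc34)nc(N3CCN(Cc4ccccc4)CC3)n2)cc1C(F)(F)F` share one core and differ only in the group carried by an amine nitrogen in a ring. In a functional assay on DU-145 cells (Homo sapiens) for cytotoxicity, read by sulforhodamine B assay, with a stated time of 48 h (a lower number here means a stronger inhibitor of growth, a higher number a weaker inhibitor of growth), compound 1 gives > 100000 nM, which is a limit of the assay rather than a number. Compound 2 in this assay gives > 100000 nM, again a limit and not a number. The step that the two limits leave unreadable from compound 1 to compound 2 is therefore unreadable, both values sitting at the limit of > 100000 nM in this assay, at which 2 of the 2 values shown sit. Compound 3 `N#Cc1ccc(Nc2nc(Oc3ccnc4ccccc34)nc(N3CCN(c4ccccc4)CC3)n2)cc1C(F)(F)F` carries phenyl in place of benzyl on an amine nitrogen in a ring. No measured step bears directly on this change, and the only step shown is itself unreadable, so nothing shown points either way. Compound 3 is therefore expected to remain at the limit in this assay, with the step that the limit leaves unreadable from compound 2 to compound 3 an estimate only. Compound 3 is estimated at 150000 nM, with a range from 30000 nM to 1000000 nM.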

Compound 3, concentration for total growth inhibition: > 100000 nM
Compound 3 was reported as a limit; the forecaster's own chance of this, stated with the estimate: 80%; the middle value lies beyond the limit too.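

Among these compounds, compound 3 gives > 100000 nM in this assay, a limit and not a number, so no step among compound 1, compound 2 and compound 3 can be read: the limit of > 100000 nM in this assay, at which 3 of the 3 values shown sit. The compounds shown leave open whether any group on the ring nitrogen would give a readable value in this assay at all.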